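Aryl swap on the urea nitrogen in the shared core series

The source may report more compounds than this note shows. Statements on the series, on what has been measured and on what is new or still open speak of the compounds shown alone.

Measured compounds in an ADME assay on HS27 cells (Homo sapiens) for antiproliferative activity, read by MTT assay, with a stated time of 24 h; a lower number here means a stronger inhibitor, a higher number a weaker inhibitor:
- compound 1, `O=C(Nc1ccc(-n2ccc3c(NC(=O)c4ccccc4)ncnc32)cc1)c1ccc(Cl)c(Cl)c1`: 5000 nM
- compound 2, `O=C(Nc1ccc(-n2ccc3c(NC(=O)c4ccccc4)ncnc32)cc1)c1ccc(Cl)c(C(F)(F)F)c1`: 5500 nM
- compound 3, `O=C(Nc1ccc(-n2ccc3c(NC(=O)c4ccccc4)ncnc32)cc1)Nc1cccc(C(F)(F)F)c1`: 4500 nM

Compound 3 holds the lowest of the three numbers, but each of its neighbours lies within the scatter of it: the step of a 1.1-fold lower number from compound 1 to compound 3 (0.05 log units; within the scatter) and the step of a 1.2-fold lower number from compound 2 to compound 3 (0.09 log units; within the scatter) are both small, so the three measured compounds are not separated in this assay.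

Compound 4 is `O=C(Nc1ccc(-n2ccc3c(NC(=O)c4ccccc4)ncnc32)cc1)Nc1cccc(Cl)c1Cl`. Its change against compound 3 is 2,3-dichlorophenyl in place of 3-(trifluoromethyl)phenyl on an amide-type nitrogen.

Within the data shown here, three measured steps bear on this change, none of them beyond the scatter. Exchanging trifluoromethyl for chloro on an aromatic carbon gave a 1.1-fold higher number from compound 1 to compound 2 (0.04 log units; within the scatter). Replacing the aryl on the carbonyl carbon with an arylamino gave a 1.1-fold lower number from compound 1 to compound 3 (0.05 log units; within the scatter) and a 1.2-fold lower number from compound 2 to compound 3 (0.09 log units; within the scatter). Halogen pattern on the outer ring and the amide-versus-urea link have both left this assay flat so far.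

The expected outcome for compound 4 is therefore a step of a 1.1-fold higher number from compound 3 to compound 4 (0.03 log units; within the scatter), not beyond the scatter. Compound 4 is estimated at 4800 nM, with a range from 2400 nM to 9600 nM.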

Compound 4, half-maximal inhibitory concentration: 7800 nM
For compound 4 the middle estimate is 1.6-fold (0.21 log units) below the measured one; the range from low to high includes it.
By their numbers in this assay, from the lowest: compounds 3, 1, 2 and 4 (each within the scatter of the next).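

Working notes on the urea nitrogen: compounds 3 and 4 are the first pair in which the urea link is held and only the aryl on the amide-type nitrogen changes, with 2,3-dichlorophenyl in place of 3-(trifluoromethyl)phenyl, and in this assay this gives a 1.7-fold higher number from compound 3 to compound 4 (0.24 log units; within the scatter) as the largest step in the series so far, though it still does not clear the scatter. The two comparisons that change the link and the outer ring together, a 1.4-fold higher number from compound 2 to compound 4 (0.15 log units; within the scatter) and a 1.6-fold higher number from compound 1 to compound 4 (0.19 log units; within the scatter), are smaller and also within the scatter, so all four compounds remain unseparated and neither this aryl change nor the swap of aryl for arylamino on the carbonyl carbon has yet produced a resolved difference at this position. No measurement here accounts for the size of these steps.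

Still open, as far as these compounds go, is whether any replacement on this nitrogen can move the number beyond the scatter, for example an aryl carrying a carboxylic acid or a dimethylamino group, or a longer alkyl chain in place of the aryl. Also open, from the compounds shown here alone, is whether replacing the benzoyl group on the other side of the shared core with an acetyl group would separate these compounds in this assay.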